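Swapping a cyclobutyl amide for a fluoropiperidine urea

The source may report more compounds than this note shows. Statements on the series, on what has been measured and on what is new or still open speak of the compounds shown alone.

Measured so far:
compound 1, `CC1CC(C(=O)N2CCc3nc(C#Cc4ccccc4)sc3C2)C1`, > 10000 nM in this assay;
compound 2, `O=S(=O)(N1CCCCC1)N1Cc2nc(C#Cc3ccccc3)sc2C1`, > 10000 nM in this assay.

In an assay on HEK293 cells for negative allosteric modulation of metabotropic glutamate receptor 5 (Homo sapiens), read by FLIPR, with a stated time of 1 h (on this read-out lower numbers stand for stronger inhibition and higher numbers for weaker inhibition), compound 1 gives > 10000 nM, which is a limit of the assay and not a number. Compound 2 likewise gives > 10000 nM, again a limit. Both values shown therefore sit at the limit of > 10000 nM in this assay, at which 2 of the 2 values shown sit, so compound 1 stands nowhere within the range of numbers the assay reports. Compound 3, `O=C(N1CCC(F)CC1)N1CCc2nc(C#Cc3ccccc3)sc2C1`, differs from compound 1 by 4-fluoropiperidin-1-yl in place of 3-methylcyclobutyl on a carbonyl carbon. Among the compounds with values here, no measured pair differing in a single place is available, so the size of this step is unknown. Since every value shown is a limit, compound 3 is expected to stay near that limit, with a step of an at least 1.2-fold lower number from compound 1 to compound 3 (0.09 log units; that floor lies within the scatter) that is not expected to exceed the scatter. Compound 3 is therefore estimated at 8000 nM, between 800 nM and 30000 nM.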

Compound 3, half-maximal inhibitory concentration: > 10000 nM
Compound 3: only a limit was reported (the forecaster's own chance of this, stated with the estimate: 60%); middle value at least 1.2-fold (0.09 log units) away from the limit.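

No step can be read from compound 1 to compound 3, because both values are limits of the assay and not numbers: the limit of > 10000 nM in this assay, at which 3 of the 3 values shown sit.

The compounds shown leave open how strongly any of them inhibits, and whether 4-fluoropiperidin-1-yl in place of 3-methylcyclobutyl changes that at all.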